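Compound 4: methyl-bearing piperidinyl ether on the shared core

A few compounds are considered here, and "the series" means these few. Any claim that something is new, unique, unknown or untested is made for them only; others in the source may bear on it.

In an assay on isolated protein for inhibition of ubiquitin carboxyl-terminal hydrolase 7 (Homo sapiens), read by fluorescence, with stated times of 30 min and 1 h (on this read-out higher numbers stand for weaker inhibition and lower numbers for stronger inhibition), compound 3 `Cc1cc(Cl)cc(-c2ccnc3cc(CN4C(=O)C5C(C4=O)C5(C)C)sc23)c1OC1CCCNC1` gives 2.4 nM, the highest of the three numbers. Compound 2 `Cc1cc(Cl)cc(-c2ccnc3cc(CN4C(=O)C5C(C4=O)C5(C)C)sc23)c1CC1CCCNC1` gives 1.3 nM, with a 1.8-fold higher number from compound 2 to compound 3 (0.27 log units; within the scatter); compound 1 `Cc1cc(Cl)cc(-c2ccnc3cc(CN4C(=O)C5C(C4=O)C5(C)C)sc23)c1C[C@@H]1CNCCO1` gives 0.44 nM, with a 5.5-fold higher number from compound 1 to compound 3 (0.74 log units; beyond the scatter). Compound 4 `Cc1cc(Cl)cc(-c2ccnc3cc(CN4C(=O)C5C(C4=O)C5(C)C)sc23)c1O[C@@H]1CCNC[C@@H]1C` differs from compound 3 by 3-methylpiperidin-4-yl in place of piperidin-3-yl on an oxygen on an aromatic ring, the saturated amine ring being re-attached and gaining a methyl while the ether link is kept. Among the compounds with values here, the only measured step that changes the amine ring itself is a 3.0-fold higher number from compound 1 to compound 2 (0.47 log units; beyond the scatter), a modest move; the other steps concern the link. A comparable, modest step is therefore expected, direction open, likely near the scatter: a 1.0-fold higher number from compound 3 to compound 4 (0.02 log units; within the scatter). Compound 4 is expected at 2.5 nM, within 0.8 nM to 8 nM.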

Compound 4, half-maximal inhibitory concentration: 0.18 nM
For compound 4 the middle estimate is 14-fold (1.14 log units) above the measured one, and the stated range ends above it.
By their numbers in this assay, from the lowest: compound 4; then compound 1; then compounds 2 and 3 (each within the scatter of the next).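

Within the data shown here, on the oxygen on an aromatic ring, the choice of amine ring matters more than the earlier compounds suggested: in this assay the change to 3-methylpiperidin-4-yl gives a 13-fold lower number from compound 3 to compound 4 (1.12 log units; beyond the scatter), the only large step. The ether link is therefore compatible with the lowest number here, as a 7.2-fold lower number from compound 2 to compound 4 (0.86 log units; beyond the scatter) and a 2.4-fold lower number from compound 1 to compound 4 (0.39 log units; beyond the scatter) show for the carbon-linked amines. Nothing available accounts for this gain.

Ring re-attachment and the added methyl change together, so their contributions stay unseparated. A plain piperidin-4-yl on the oxygen would separate them, and an ethyl in place of the methyl would probe that substituent further.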